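The source may hold more compounds than are shown below. What is called first, only, known or untested is meant among the compounds shown, and "the series" means these compounds.

Compound 3 `O=C1O[C@@H](Cn2ccnn2)CN1c1ccc(-n2cc(-c3ccccn3)cn2)c(F)c1` carries the shared core with a (1H-1,2,3-triazol-1-yl)methyl group on a saturated ring carbon. For the measured compounds named here, in a physicochemical assay for solubility, read by HPLC, with a stated time of 24 h (on this read-out higher numbers stand for higher solubility and lower numbers for lower solubility), compound 3 gives 247000 nM, the second highest of the three numbers measured so far. Compound 1 `O=C1O[C@@H](CN2CCCCC2)CN1c1ccc(-n2cc(-c3ccccn3)cn2)c(F)c1` gives 219000 nM in this assay, and compound 2 `CC(=O)OC[C@H]1CN(c2ccc(-n3cc(-c4ccccn4)cn3)c(F)c2)C(=O)O1` gives 373000 nM. All three differ only in the group on this carbon, and every step among them stays within the scatter: a 1.7-fold higher number from compound 1 to compound 2 (0.23 log units; within the scatter), a 1.1-fold higher number from compound 1 to compound 3 (0.05 log units; within the scatter) and a 1.5-fold lower number from compound 2 to compound 3 (0.18 log units; within the scatter).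

Compound 4 `NC(=O)[C@H]1CN(c2ccc(-n3cc(-c4ccccn4)cn3)c(F)c2)C(=O)O1` is not yet measured. It differs from compound 3 by carbamoyl in place of (1H-1,2,3-triazol-1-yl)methyl on a saturated ring carbon. Going by the values given here, no measured step involves a carbamoyl group, so the change is not directly covered. Still, because a 1.7-fold higher number from compound 1 to compound 2 (0.23 log units; within the scatter) is the largest of the three steps among compounds 1, 2 and 3 in this assay and all of them lie within the scatter, a change at this position is expected to move the number little. Compound 4 is therefore expected to give about 260000 nM, within a range of 120000 nM to 550000 nM, which would mean an expected step of a 1.1-fold higher number from compound 3 to compound 4 (0.02 log units; within the scatter).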

Compound 4, solubility: 27200 nM
Compound 4: middle estimate off by 9.6-fold (0.98 log units), on the high side; measured number below the stated range.
By their numbers in this assay, from the lowest: compound 4; then compounds 1, 3 and 2 (each within the scatter of the next).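

In this assay this position turns out to be able to move the number beyond the scatter, which no step among compounds 1, 2 and 3 had shown, with a 9.1-fold lower number from compound 3 to compound 4 (0.96 log units; beyond the scatter) and a 14-fold lower number from compound 2 to compound 4 (1.14 log units; beyond the scatter) and an 8.1-fold lower number from compound 1 to compound 4 (0.91 log units; beyond the scatter) on placing carbamoyl on this carbon. Set against compound 3, the change is to a smaller group, 3 heavy atoms in place of 6, with no ring and with 1 hydrogen-bond donor where the group that leaves has 0. Nothing at hand accounts for these steps.

The compounds shown do not separate the loss of the methyl link from the arrival of the carbamoyl group itself. A carbamoylmethyl group or a carboxylic acid on this same carbon would help tell the two apart.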